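The source may report more compounds than this note shows. Statements on the series, on what has been measured and on what is new or still open speak of the compounds shown alone.

Values in an ADME assay on HepG2 cells (Homo sapiens) for inhibition, read by fluorescence and resazurin assay, with a stated time of 72 h; a lower number here means a stronger inhibitor, a higher number a weaker inhibitor:
- Compound 1 `NS(=O)(=O)c1cccc(Nc2nccc(Nc3ccc4nc[nH]c4c3)n2)c1`: > 25000 nM
- Compound 2 `Cc1cccc(Nc2nccc(Nc3ccc4cn[nH]c4c3)n2)c1`: 15000 nM
- Compound 3 `CN1CCN(c2cccc(Nc3nccc(Nc4ccc5nc[nH]c5c4)n3)c2)CC1`: not yet measured

Compound 1 stands at a limit of the assay, not at a number: the limit of > 25000 nM in this assay, at which 1 of the 2 values shown sits. Compound 3 carries 4-methylpiperazin-1-yl in place of sulfamoyl on an aromatic carbon of compound 1 (4-methylpiperazin-1-yl in place of sulfamoyl on an aromatic carbon). Among the measured compounds shown here, no measured pair shows this change, so any expectation is loose. Compound 2 gives a true number at 15000 nM, which suggests that compound 3 could also give one. The expected step is an at least 2.0-fold lower number from compound 1 to compound 3 (0.31 log units; beyond the scatter), modest in size and towards stronger inhibition. For compound 3 the estimate is 12000 nM, with an expected range of 4000 nM to 25000 nM.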

Compound 3, half-maximal inhibitory concentration: 11000 nM
Beside the measured number, compound 3's estimate is 1.1-fold (0.04 log units) above it; measured number inside the range.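

In this assay, placing 4-methylpiperazin-1-yl instead of sulfamoyl on this aromatic carbon gives an at least 2.2-fold lower number from compound 1 to compound 3 (0.35 log units; beyond the scatter), so the group held here can move the result on the core of compound 1. The true size of the step stays unknown, since compound 1 stands at a limit of the assay and not at a number: the limit of > 25000 nM in this assay, at which 1 of the 3 values shown sits.

With only these two groups shown at this position, the effect of a simple dimethylamino group or a carboxylic acid there remains open. Going by these compounds, whether the whole 4-methylpiperazin-1-yl group is needed also remains open.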